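An aryl replaces an amide on the ring nitrogen

This account rests on a few compounds, and the source may have more. Where it says the series, first, only, none or still open, it means among the compounds named here.

The measured compounds in an ADME assay on HEp-2 cells (Homo sapiens) for cytotoxicity, read by CCK-8 assay, with a stated time of 6 days; on this read-out higher numbers stand for lower toxicity in this test and lower numbers for higher toxicity in this test:
- Compound 1, `CCC(=O)N1CCN(c2cc(NCCN)c3ccccc3n2)CC1`, reaches only the limit > 100000 nM.
- Compound 2, `NCCNc1cc(N2CCN(C(=O)C3CCCCC3)CC2)nc2ccccc12`, reaches only the limit > 100000 nM.
- Compound 3, `CC(C)CC(=O)N1CCN(c2cc(NCCN)c3ccccc3n2)CC1`, reaches only the limit > 100000 nM.

Compound 3 thus stands at the limit of this assay, with no number of its own; the same holds for the other two measured compounds, as the line the limit of > 100000 nM in this assay, at which 3 of the 3 values shown sit, records. The steps among them, a step that the two limits leave unreadable from compound 1 to compound 2, a step that the two limits leave unreadable from compound 1 to compound 3 and a step that the two limits leave unreadable from compound 2 to compound 3, are all left unreadable by the limits, so none of them gives a size that can be carried over.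

Compound 4, `NCCNc1cc(N2CCN(c3cccc(Cl)c3)CC2)nc2ccccc12`, differs from compound 3 as follows: 3-chlorophenyl in place of isobutylcarbonyl on an amine nitrogen in a ring. Among the measured compounds shown here, this change is unlike any of the measured steps, which altered only the group on the carbonyl side, so no measured step bears on it directly. The three limits show no toxicity to be read at all in this series. The author therefore expects compound 4 to stay near the limit, with the change estimated as a number no higher from compound 3 to compound 4 (the limit leaves the size open), and estimates its value in this assay at 100000 nM, within 30000 nM to 300000 nM.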

Compound 4, half-maximal cytotoxic concentration: 6400 nM
The estimate for compound 4 lay 16-fold (1.19 log units) above the measured number; the measured number lies below the stated range.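

Among the compounds shown here, on an amine nitrogen in a ring, this change is the first to give a readable shift: in this assay, 3-chlorophenyl in place of isobutylcarbonyl gives an at least 15-fold lower number from compound 3 to compound 4 (1.19 log units; beyond the scatter), while the same aryl gives an at least 15-fold lower number from compound 2 to compound 4 (1.19 log units; beyond the scatter) in place of cyclohexylcarbonyl and an at least 15-fold lower number from compound 1 to compound 4 (1.19 log units; beyond the scatter) in place of propanoyl. So the group on this nitrogen can change the read-out, whereas the steps among compound 1, compound 2 and compound 3 cannot be read. Compound 1, compound 2 and compound 3 each stand only at a limit: the limit of > 100000 nM in this assay, at which 3 of the 4 values shown sit.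

The compounds shown do not separate the loss of the carbonyl from the entry of the aromatic ring or of the chlorine. Going by these compounds, a plain phenyl or a benzoyl group on the same nitrogen is absent from them, so which part of the change carries the step stays open.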